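Ring amide nitrogen aryl swap: compound 3 to compound 4

The compounds below may be only part of what the source reports. "The series", "measured", "known", "first", "only" and "open" are said of these compounds alone.

The series shares one core and varies the aryl group on the amide-type nitrogen in the ring. In a functional assay on HEK293 cells for positive allosteric modulation of metabotropic glutamate receptor 5 (Homo sapiens), read by calcium flux (a lower number here means a smaller maximal response, a higher number a larger maximal response), compound 1 `O=C1c2cc(COc3ccccc3)nn2CCN1c1ccccc1F` gives 86%, compound 2 `O=C1c2cc(COc3ccccc3)nn2CCN1c1ccc(F)cc1` gives 79%, and compound 3 `Cc1ccc(N2CCn3nc(COc4ccccc4)cc3C2=O)nc1` gives 76%. The three numbers sit close together: a number 7 percentage points lower from compound 1 to compound 2 (within the scatter), a number 10 percentage points lower from compound 1 to compound 3 (within the scatter) and a number 3 percentage points lower from compound 2 to compound 3 (within the scatter). On these numbers compound 3 is the lowest of the three, but both gaps to it fall within the scatter, so no ordering among the three is supported.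

Compound 4 `O=C1c2cc(COc3ccccc3)nn2CCN1c1ncc(F)cn1` is not yet measured. It differs from compound 3 in one place: 5-fluoropyrimidin-2-yl in place of 5-methylpyridin-2-yl on an amide-type nitrogen in a ring.

All three measured steps bear on this change, since each swaps the aryl group on the same nitrogen, and none of them moved the maximal response beyond the scatter; the step from compound 2 to compound 3, which also exchanges a phenyl-type ring for a pyridine-type ring, was the smallest of the three. Nothing in the measured set shows a shift of this read-out from any aryl exchange at this position. The expectation for compound 4 is therefore a step of a number 2 percentage points higher from compound 3 to compound 4 (within the scatter), which is no change beyond the scatter. Compound 4 is estimated at 78%, with a range from 65% to 91%.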

Compound 4, largest response reached (Emax), in percent of the reference or control that the assay uses: 72%
Beside the measured number, compound 4's estimate is 6 percentage points above it, within the range that was stated.
By their numbers in this assay, from the lowest: compounds 4, 3, 2 and 1 (each within the scatter of the next, the first and the last beyond it).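

In this assay, among these compounds, the swap to 5-fluoropyrimidin-2-yl gives the first step beyond the scatter at the amide-type nitrogen in a ring, a modest one against the 2-fluorophenyl group (a number 14 percentage points lower from compound 1 to compound 4 (beyond the scatter)). The same group stays within the scatter against the other two aryl groups (a number 4 percentage points lower from compound 3 to compound 4 (within the scatter); a number 7 percentage points lower from compound 2 to compound 4 (within the scatter)), so compound 2 and compound 3 fall within the scatter of both compound 1 and compound 4, and only the two ends of the set separate, with no graded trend across the four compounds. No measurement among the data shown accounts for the step from compound 1 to compound 4, so the part played by the added ring nitrogen, the fluorine or their place in the ring stays unassigned.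

Open, from the compounds shown here alone, is how an unsubstituted phenyl or a plain pyrimidin-2-yl group on this nitrogen would compare with compound 1 and compound 4, a comparison that would separate the contribution of the ring nitrogens from that of the fluorine. Also open, going by these compounds, is whether a saturated ring such as cyclohexyl on the same nitrogen would keep the maximal response within the scatter of these aryl compounds.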